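The compounds below may be only part of what the source reports. "The series", "measured", "known", "first", "only" and "open" are said of these compounds alone.

Measured so far:
- compound 1 `O=C(c1cccnc1)N1CCC(NS(=O)(=O)c2cc(S(=O)(=O)c3ccccc3)ccc2C(F)(F)F)CC1` gives 0.0333 h
- compound 2 `O=C(c1ccc(Cl)nc1)N1CCC(NS(=O)(=O)c2cc(S(=O)(=O)c3ccccc3)ccc2C(F)(F)F)CC1` gives 0.15 h

In an in vitro ADME assay on microsomes from liver (Rattus norvegicus) for metabolic stability, tested at 1 uM (on this read-out lower numbers stand for a shorter-lived compound and higher numbers for a longer-lived compound), compound 2 has the higher of the two numbers, at 0.15 h. The next compound to be measured is compound 3 `O=C(O)c1cccc(S(=O)(=O)N2CCC(NS(=O)(=O)c3cc(S(=O)(=O)c4ccccc4)ccc3C(F)(F)F)CC2)c1`. It replaces the whole group on the amine nitrogen in a ring, leaving the rest of the molecule as it is: (3-carboxyphenyl)sulfonyl in place of (6-chloropyridin-3-yl)carbonyl on an amine nitrogen in a ring. Within the data shown here, only one measured step bears on this: a 4.5-fold higher number from compound 1 to compound 2 (0.65 log units; beyond the scatter), with chloro in place of hydrogen on an aromatic carbon. That step was modest but beyond the scatter, and it took place within the group that now leaves. In this single pair, then, a small edit at this end of the molecule moved the half-life. Among the measured compounds shown here, no measured compound carries the (3-carboxyphenyl)sulfonyl group, so the direction is only a loose expectation. A modest rise of similar size is expected, the estimated change being a 2.7-fold higher number from compound 2 to compound 3 (0.43 log units; beyond the scatter). For compound 3 the estimated half-life is 0.4 h, within an expected range of 0.08 h to 2 h.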

Compound 3, half-life: 0.383 h
Beside the measured number, compound 3's estimate is 1.0-fold (0.02 log units) above it; low and high end bracket the measured number.
By their numbers in this assay, from the lowest: compound 1; then compound 2; then compound 3.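

In this assay, the earlier pair showed only that a single chloro on the ring of the leaving group goes with a longer half-life. Compound 3 shows that the entire group on the amine nitrogen in a ring can be exchanged for one with a different link and a different ring, and the number still rises (a 2.6-fold higher number from compound 2 to compound 3 (0.41 log units; beyond the scatter)). Measured against the unsubstituted (pyridin-3-yl)carbonyl group, the same exchange is a large step (a 12-fold higher number from compound 1 to compound 3 (1.06 log units; beyond the scatter)), so this end of the molecule can shift the half-life by much more than the first pair suggested, and no evidence here explains why.

The new group changes several things at once: a sulfonyl replaces the carbonyl, a carbon-only ring replaces the pyridine, and a carboxylic acid replaces the chloro, so the compounds shown cannot say which of these carries the rise. A plain phenylsulfonyl group, or a methyl ester in place of the carboxylic acid, would begin to pull these changes apart.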